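Ring methyl removal in a polyunsaturated chromone series

The compounds below may be only part of what the source reports. "The series", "measured", "known", "first", "only" and "open" are said of these compounds alone.

Compound 1 `CC/C=C\C/C=C\C/C=C\CCCCCCCc1cc(=O)c2c(O)cc(OCOC)c(C)c2o1`, compound 2 `CC/C=C\C/C=C\C/C=C\CCCCCCCc1cc(=O)c2c(O)cc(OCOC)cc2o1` and compound 3 `CC/C=C\C/C=C\C/C=C\CCCCCCCc1cc(=O)c2c(O)c(C)c(O)c(C)c2o1` carry the same long unsaturated chain and differ only in how the carbocyclic ring is substituted. In a functional assay on MDA-MB-231 cells (Homo sapiens) for antiproliferative activity, read by MTT assay (on this read-out lower numbers stand for stronger inhibition and higher numbers for weaker inhibition), compound 1 gives 6790 nM. In this assay compound 2 gives 6790 nM. Compound 3 gives 6790 nM in this assay. The step of no change at the digits printed from compound 1 to compound 2 (within the scatter) corresponds to the change (hydrogen in place of methyl on an aromatic carbon). The difference between the cores of compound 1 and compound 3 is not broken down here; their two values are level at the digits reported, within the scatter.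

Compound 4 `CC/C=C\C/C=C\C/C=C\CCCCCCCc1cc(=O)c2c(O)c(C)c(O)cc2o1` has not yet been measured. It arises from compound 3 by hydrogen in place of methyl on an aromatic carbon. Going by the values given here, this is the same kind of change as the one made from compound 1 to compound 2, but the surroundings are not identical: in compound 1 the carbon is ortho to a methoxymethoxy group, whereas in compound 3 it is ortho to a hydroxy group and meta to a methyl group; in both cases it is ortho to a fused ring, meta to a fused ring and para to a hydroxy group.

The step expected in this assay is no change at the digits printed from compound 3 to compound 4 (within the scatter). This expectation rests on the earlier step of no change at the digits printed from compound 1 to compound 2 (within the scatter), which lies within the scatter, and on compound 3 sitting level with compound 1 and compound 2. The estimate for compound 4 in this assay is 6790 nM, with an expected range from 3400 nM to 13600 nM.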

Compound 4, half-maximal inhibitory concentration: 6790 nM
Compound 4: middle estimate and measured number agree at the digits printed, within the range that was stated.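

In this assay, hydrogen in place of methyl on an aromatic carbon gives no change at the digits printed from compound 3 to compound 4 (within the scatter), and the same change on the other core gives no change at the digits printed from compound 1 to compound 2 (within the scatter). The two steps agree, so on these two cores the change carries over with no visible gap: the same change on two cores in this assay, no change at the digits printed (within the scatter) from compound 1 to compound 2 and no change at the digits printed (within the scatter) from compound 3 to compound 4, 1.0-fold (0.00 log units) apart, within the scatter of two such steps

This shows only that the replacement leaves the read-out unmoved on two cores, one carrying a methoxymethoxy group and the other a hydroxy group in its place; it does not show that the methyl groups are without any role, that the same would hold on a third core, or that it would hold in another read-out, and two flat steps give no size of effect to transfer.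

Open, as far as these compounds go, is whether the step stays flat when the ring hydroxy group gives way to an amine or a carboxylic acid, or when the long unsaturated chain gives way to a shorter saturated chain. Also open, from the compounds shown here alone, is what hydrogen in place of the remaining methyl group of compound 4 would do, which would show whether the ring needs any methyl group at all.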